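Notes on hydroxy in place of chloromethyl

The source may hold more compounds than are shown below. What is called first, only, known or untested is meant among the compounds shown, and "the series" means these compounds.

Measured in a functional assay on HeLa cells (Homo sapiens) for antiproliferative activity, read by MTT assay, with a stated time of 72 h; a higher number here means a weaker inhibitor, a lower number a stronger inhibitor:

- compound 1 `O=C1O[C@H]([C@@H](O)Cn2cc(CNS(=O)(=O)c3ccc(F)cc3)nn2)C(OCc2ccccc2)=C1OCc1ccccc1` gives 25000 nM
- compound 2 `O=C1O[C@H]([C@@H](O)Cn2cc(CNS(=O)(=O)c3ccc(Cl)cc3)nn2)C(OCc2ccccc2)=C1OCc1ccccc1` gives 13600 nM
- compound 3 `O=C1O[C@H]([C@@H](O)Cn2cc(CCCCl)nn2)C(OCc2ccccc2)=C1OCc1ccccc1` gives 36700 nM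

Compound 3 lies within the scatter of compound 1 and stands a modest step apart from compound 2. The next structure is compound 4 `O=C1O[C@H]([C@@H](O)Cn2cc(CCO)nn2)C(OCc2ccccc2)=C1OCc1ccccc1`, with this change from compound 3: hydroxy in place of chloromethyl on a saturated chain carbon, two bonds along the chain from an aromatic carbon. Hydroxy stands in place of chloromethyl on a saturated chain carbon, two bonds along the chain from an aromatic carbon, so 3-chloropropyl becomes 2-hydroxyethyl. For the measured compounds named here, no measured step covers this exact change. The closest evidence is the exchange of the larger group that separates compound 3 from the two sulfonylamino compounds, which gave a 1.5-fold higher number from compound 1 to compound 3 (0.17 log units; within the scatter) and a 2.7-fold higher number from compound 2 to compound 3 (0.43 log units; beyond the scatter). On those sizes, no step beyond the scatter is expected in this assay, and neither direction is favoured. For compound 4 the estimated step is a 1.2-fold lower number from compound 3 to compound 4 (0.09 log units; within the scatter). Compound 4 is expected at 30000 nM, with an estimated range of 11000 nM to 85000 nM.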

Compound 4, half-maximal inhibitory concentration: 68800 nM
Compound 4: the middle estimate sits 2.3-fold (0.36 log units) below what was measured; the measured number falls inside the stated range.
By their numbers in this assay, from the lowest: compounds 2, 1, 3 and 4 (each within the scatter of the next, the first and the last beyond it).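

In this assay, replacing chloromethyl with hydroxy, which turns 3-chloropropyl into 2-hydroxyethyl, gives a step within the scatter (a 1.9-fold higher number from compound 3 to compound 4 (0.27 log units; within the scatter)). Unlike compound 3, which stood beyond the scatter only from compound 2, compound 4 lies beyond it from both sulfonylamino compounds (a 5.1-fold higher number from compound 2 to compound 4 (0.70 log units; beyond the scatter); a 2.8-fold higher number from compound 1 to compound 4 (0.44 log units; beyond the scatter)). No measurement at hand accounts for these steps.

This change alters the chain and its end group together, so a longer chain ending in hydroxy, or a 2-chloroethyl chain, would be needed to read the two apart. As far as these compounds go, whether an amine or a carboxylic acid on the same saturated chain carbon would stay with compound 3 and compound 4 also remains open.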